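The source may report more compounds than this note shows. Statements on the series, on what has been measured and on what is new or still open speak of the compounds shown alone.

The three measured compounds, with their results in an assay on isolated protein for inhibition of vascular endothelial growth factor receptor 1 (Homo sapiens), read by HTRF, tested at 10 uM; on this read-out higher numbers stand for more inhibition at the one concentration tested (going by the name of the read-out) and lower numbers for less inhibition:

compound 1 `Cc1cccc(N(C)c2cc(Nc3cccc(C(=O)N(CC(C)C)CC(C)C)c3)ncn2)c1` gives 5%
compound 2 `Cc1cccc(Oc2ccnc(N3CCN(C(=O)c4c(C)noc4C)CC3)n2)c1` gives 7%
compound 3 `Cc1cccc(Oc2ccnc(N3CCC[C@H]3C(=O)NCCCn3ccnc3)n2)c1` gives 0%

Compound 3 stands at the lowest of the three numbers in this assay, but its gap to compound 1 and its gap to compound 2 both lie within the scatter of repeated measurements, so the three compounds cannot be told apart on this read-out: all three sit close to no inhibition at the single concentration tested.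

Compound 4 `COC(=O)C(CO)NC(=O)[C@@H]1CCCN1c1nccc(Oc2cccc(C)c2)n1` has not yet been measured. It differs from compound 3 in one place: 2-hydroxy-1-(methoxycarbonyl)ethyl in place of 3-(1H-imidazol-1-yl)propyl on an amide-type nitrogen. Within the data shown here, no pair of measured compounds in this set differs in a single place, so there is no measured step that would show how such a change moves the read-out. With none of the three measured compounds departing from the baseline, the change is expected to bring no movement beyond the scatter, a number 5 percentage points higher from compound 3 to compound 4 (within the scatter). Compound 4 is therefore estimated at 5% in this assay, with a range from -5% to 15%.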

Compound 4, a percentage reported as inhibition, at one concentration (the size of the read-out at that concentration, not a potency): 0%
For compound 4 the middle estimate is 5 percentage points above the measured one, within the range that was stated.
By their numbers in this assay, from the lowest: compounds 3, 4, 1 and 2 (each within the scatter of the next).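

In this assay, among these compounds, putting 2-hydroxy-1-(methoxycarbonyl)ethyl in place of 3-(1H-imidazol-1-yl)propyl on the amide-type nitrogen gives no change at the digits printed from compound 3 to compound 4 (within the scatter) and is the first single-place step in this set. It shows that an open chain with no ring and a chain carrying a five-membered aromatic ring cannot be told apart at this position, with both compounds reading close to no inhibition. No measurement shown offers a reason for this result.

On these data alone, whether any group on this nitrogen can lift the read-out clear of the scatter stays open. A carboxylic acid in place of the methoxycarbonyl, an aminoalkyl chain or a longer chain could each test this, and the compounds shown do not say how any of them would read.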